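A few compounds are considered here, and "the series" means these few. Any claim that something is new, unique, unknown or untested is made for them only; others in the source may bear on it.

Compound 1, `CC(=O)Nc1ccc(S(=O)(=O)Nc2ccc(Oc3ccc(Cl)c(C(F)(F)F)c3)c(C#N)c2)cc1`: 64%
Compound 2, `N#Cc1cc(NS(=O)(=O)c2ccc(NC(=O)N3CCOCC3)cc2)ccc1Oc1ccc(Cl)c(C(F)(F)F)c1`: 64%
Compound 3, `N#Cc1cc(NS(=O)(=O)c2ccc(N)cc2)ccc1Oc1ccc(Cl)c(C(F)(F)F)c1`: 67%

In an assay for inhibition of platelet-activating factor acetylhydrolase (Rattus norvegicus), in plasma, with stated times of 30 min and 10 min, tested at 250 nM (on this read-out lower numbers stand for less inhibition and higher numbers for more inhibition at the one concentration tested (going by the name of the read-out)), the three numbers lie close together. The step of a number 3 percentage points higher from compound 1 to compound 3 (within the scatter) and the step of a number 3 percentage points higher from compound 2 to compound 3 (within the scatter) are both within the scatter, as is the step of no change at the digits printed from compound 1 to compound 2 (within the scatter), so compound 3 cannot be set apart from compound 1 or compound 2 on these numbers; its value simply sits alongside theirs.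

Compound 4, `CC(=O)NCc1ccc(S(=O)(=O)Nc2ccc(Oc3ccc(Cl)c(C(F)(F)F)c3)c(C#N)c2)cc1`, differs from compound 3 by one change: acetamidomethyl in place of amino on an aromatic carbon. The measured steps that touch this place are the two that end at compound 3, in which acetyl or (morpholin-4-yl)carbonyl on the ring nitrogen gave way to hydrogen, and neither moved the read-out beyond the scatter. None of the three measured compounds, however, carries the nitrogen one bond away from the ring, so the acetamidomethyl group of compound 4 is not covered directly. On the available evidence the expectation is a step of a number 5 percentage points lower from compound 3 to compound 4 (within the scatter) that stays within the scatter, with no direction favoured. Compound 4 is therefore estimated to give 62% in this assay, with a range from 45% to 78%.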

Compound 4, a percentage reported as inhibition, at one concentration (the size of the read-out at that concentration, not a potency): 80%
Compound 4: middle estimate off by 18 percentage points, on the low side; measured number above the stated range.
By their numbers in this assay, from the lowest: compounds 1, 2 and 3 (each within the scatter of the next); then compound 4.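

In this assay, the earlier exchanges on the ring nitrogen had all stayed within the scatter, so this position had seemed indifferent; moving to 4-(acetamidomethyl)phenyl from 4-aminophenyl now gives a number 13 percentage points higher from compound 3 to compound 4 (beyond the scatter). The acetamido group of compound 1 and the acetamidomethyl group of compound 4 both carry an acetyl on a nitrogen, yet the read-out gives a number 16 percentage points higher from compound 1 to compound 4 (beyond the scatter), and the ((morpholin-4-yl)carbonyl)amino group gives a step of the same size, a number 16 percentage points higher from compound 2 to compound 4 (beyond the scatter), so among these four compounds the read-out separates the one group with its nitrogen one bond away from the ring from the three with that nitrogen on the ring. No supporting measurement bears on why this difference appears.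

The compounds shown leave open whether the aminomethyl group, without the acetyl, would stand with compound 4 or with compound 3. They also leave open how a longer chain such as acetamidoethyl, or a carboxylic acid on the same aromatic carbon, would read at this single concentration, which gives no potency.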